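Chloro to fluoro: what binding to expect for compound 4

The source may report more compounds than this note shows. Statements on the series, on what has been measured and on what is new or still open speak of the compounds shown alone.

Of the compounds shown here, three that share one core have been measured in an assay on isolated protein for binding affinity to 5-hydroxytryptamine receptor 1D (Homo sapiens); a higher number here means a weaker inhibitor, a lower number a stronger inhibitor. Compound 1 `Cc1ccc(-c2n[nH]cc2N2CCCNCC2)cc1` gives 892 nM, compound 2 `Clc1ccc(-c2n[nH]cc2N2CCCNCC2)cc1` gives 1230 nM, and compound 3 `Fc1cccc(-c2n[nH]cc2N2CCCNCC2)c1` gives 2540 nM. Among these three numbers, compound 2 stands second highest; its nearest neighbour is compound 1, whose number lies within the scatter of it, while compound 3 shows a larger number that lies beyond the scatter.

Compound 4 `Fc1ccc(-c2n[nH]cc2N2CCCNCC2)cc1` has not yet been measured. It differs from compound 2 in one place: fluoro in place of chloro on an aromatic carbon. Within the data shown here, the only measured step that bears on this position is a 1.4-fold higher number from compound 1 to compound 2 (0.14 log units; within the scatter), which exchanged one group for another at that same place and left the number where it was. Among the measured compounds shown here, no measured pair sets fluoro against chloro directly, and the one fluoro compound that is known, compound 3, carries its fluoro in a different place, so its value is only a loose guide.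

On this basis, in this assay the expected step is a 1.2-fold higher number from compound 2 to compound 4 (0.09 log units; within the scatter), with no change beyond the scatter the most likely outcome. Compound 4 is therefore estimated at 1500 nM, with a range from 700 nM to 3300 nM.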

Compound 4, inhibition constant: 2190 nM
Beside the measured number, compound 4's estimate is 1.5-fold (0.16 log units) below it; low and high end bracket the measured number.
By their numbers in this assay, from the lowest: compounds 1, 2, 4 and 3 (each within the scatter of the next, the first and the last beyond it).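

In this assay, among these compounds, the first direct comparison of fluoro with chloro on this aromatic carbon, para to a large group, gives a 1.8-fold higher number from compound 2 to compound 4 (0.25 log units; within the scatter), so this exchange alone does not separate the two compounds beyond the usual spread of repeat measurements. Compared with methyl at the same place, however, fluoro gives a 2.5-fold higher number from compound 1 to compound 4 (0.39 log units; beyond the scatter): this is the first change at this position that clears the scatter, and it shows that the position does respond to the choice of group, though only modestly, since each of the two smaller steps linking methyl, chloro and fluoro stays within the scatter while the step across the whole set does not. No measurement available here accounts for this difference between methyl and fluoro.

All three groups compared at this place are small, so these compounds say nothing about how binding would respond to a very different group there, such as an amine, a carboxylic acid or a longer chain. They also leave open whether any group at this position could move binding much further than this narrow range, in either direction.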